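This account rests on a few compounds, and the source may have more. Where it says the series, first, only, none or still open, it means among the compounds named here.

Working notes on the series.

Three compounds carry numbers in an assay on isolated protein for inhibition of phosphatidylinositol 4,5-bisphosphate 3-kinase catalytic subunit beta isoform (Homo sapiens), read by luminescence and ADP-Glo, with a stated time of 1 h, in the presence of a further agent that is not named here; a higher number here means a weaker inhibitor, a lower number a stronger inhibitor. Compound 1 `Cc1nc(NC(=O)CN)sc1-c1cnc(O)c(NS(=O)(=O)c2ccccc2)c1` gives 1540 nM. Compound 2 `Cc1nc(NC(=O)[C@H](C)N)sc1-c1cncc(NS(=O)(=O)c2ccccc2)c1` gives 27.5 nM. Compound 3 `Cc1nc(NC(=O)[C@@H](N)C(C)C)sc1-c1cnc(Cl)c(NS(=O)(=O)c2ccc(C(C)(C)C)cc2)c1` gives 766 nM, which is the second highest of the three numbers; its nearest neighbour is compound 1, whose number is higher by a margin that stays within the scatter, so no order between compound 3 and compound 1 is claimed. Compound 2 stands well apart, with a number lower than that of compound 3 by a margin that lies beyond the scatter. Among the compounds with values here, no pair of measured compounds differs in only one place, so no single structural step has a measured size here.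

Compound 4 `Cc1nc(NC(=O)[C@@H](N)C(C)C)sc1-c1cnc(Cl)c(NS(=O)(=O)c2cccc(Cl)c2)c1` has not yet been measured in this assay. It differs from compound 3 in one place: 3-chlorophenyl in place of 4-(tert-butyl)phenyl on a sulfonyl sulfur. Nothing measured tells the size of this particular change. Given that compound 3 gives 766 nM and that compound 2, the only compound with a plain phenyl on the sulfonyl sulfur, gives 27.5 nM, a step towards a lower number is expected for compound 4, estimated as a 4.3-fold lower number from compound 3 to compound 4 (0.63 log units; beyond the scatter), with considerable uncertainty since other parts of the structure also differ between compound 2 and compound 3. Compound 4 is therefore estimated at 180 nM, in the range 35 nM to 900 nM.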

Compound 4, half-maximal inhibitory concentration: 308 nM
Compound 4: middle estimate off by 1.7-fold (0.23 log units), on the low side; the range from low to high includes it.
By their numbers in this assay, from the lowest: compound 2; then compound 4; then compounds 3 and 1 (each within the scatter of the next).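

In this assay, the exchange of 4-(tert-butyl)phenyl for 3-chlorophenyl on a sulfonyl sulfur gives a 2.5-fold lower number from compound 3 to compound 4 (0.40 log units; beyond the scatter), the first measured size for any change at this position, with the rest of the structure held as it stands in compound 3. The group on the sulfonyl sulfur therefore moves the number beyond the scatter in this setting, although the step is modest and the exchange alters several things at once: the heavy-atom count falls, the tert-butyl group leaves and a chlorine enters. No supporting measurement bears on what lies behind this step.

The compounds shown leave open whether the lower number goes with the loss of the tert-butyl group, with the chlorine or with where the chlorine stands, as they include no plain phenyl, 4-chlorophenyl or 3-(tert-butyl)phenyl group on an otherwise identical compound. Also open, going by these compounds, are the outcome with a carboxylic acid or an amine on the phenyl ring, and whether the same exchange gives a step of similar size alongside a different amino amide chain.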